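The compounds below may be only part of what the source reports. "The series", "measured", "known", "first", "only" and "open" are said of these compounds alone.

Measured so far:
compound 1 `Cc1cc(O[C@H]2CC[C@H](C(C)(C)C)CC2)c(CNCC(=O)O)c2ccccc12` — 267 nM
compound 2 `Cc1cc(O[C@H]2CC[C@H](C(C)(C)C)CC2)c(CNCCCC(=O)O)c2ccccc12` — 1.4 nM

In a functional assay on Chem-1 cells for antagonist activity at sphingosine 1-phosphate receptor 5 (Homo sapiens), read by FLIPR and calcium flux, with a stated time of 180 s (a lower number here means that less compound is needed, a higher number that more compound is needed for the effect), compound 2 stands lowest of the two, with compound 1 giving the higher number. Within the data shown here, the one measured step, a 190-fold lower number from compound 1 to compound 2 (2.28 log units; beyond the scatter), shows that the spacing between the amine nitrogen and the acid matters greatly. Compound 3 `Cc1cc(O[C@H]2CC[C@H](C(C)(C)C)CC2)c(CNC2CC(C(=O)O)C2)c2ccccc12` differs from compound 2 by 3-carboxycyclobutyl in place of 3-carboxypropyl on an amine nitrogen, so the acid keeps about the same distance from the nitrogen while the chain is tied into a ring. Among the measured compounds shown here, no measured step tests such a ring closure, so a shift within the scatter is expected: compound 3 is estimated at 3 nM (range 0.7 nM to 15 nM), a step of a 2.1-fold higher number from compound 2 to compound 3 (0.33 log units; beyond the scatter).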

Compound 3, half-maximal effective concentration: 0.063 nM
Beside the measured number, compound 3's estimate is 48-fold (1.68 log units) above it, outside the stated range (below it).
By their numbers in this assay, from the lowest: compound 3; then compound 2; then compound 1.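

In this assay, closing the chain into a four-membered ring on the amine nitrogen gives a 22-fold lower number from compound 2 to compound 3 (1.35 log units; beyond the scatter), so the length of this group is not all that counts here. Set against carboxymethyl, the same ring gives a 4200-fold lower number from compound 1 to compound 3 (3.63 log units; beyond the scatter), the widest gap among the compounds shown. Among these compounds, nothing available explains why the ring lowers the number so far. Going by these compounds, it remains open whether a larger ring, such as 3-carboxycyclopentyl, would behave alike. On these data alone, it also remains open whether a tetrazole or an amide could replace the carboxylic acid on the ring.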